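Adding a (pyridin-4-yl)oxy group to compound 1

The source may hold more compounds than are shown below. What is called first, only, known or untested is meant among the compounds shown, and "the series" means these compounds.

Two compounds have been measured in a functional assay on CHO cells for positive allosteric modulation of metabotropic glutamate receptor 2 (Homo sapiens), read by scintillation counting and GTPgammaS binding, with a stated time of 30 min; on this read-out higher numbers stand for an effect only at larger amounts of compound and lower numbers for an effect already at smaller amounts:

Compound 1 `CC(C)CCn1ccc(-c2ccccc2)c(C#N)c1=O`: 8510 nM
Compound 2 `COc1cccc(-c2ccn(CCC(C)C)c(=O)c2C#N)c1`: 3170 nM

Within the data shown here, compound 1 has the highest of these two numbers; its nearest neighbour is compound 2, and the only measured step is a 2.7-fold lower number from compound 1 to compound 2 (0.43 log units; beyond the scatter), a modest move that comes from putting methoxy in place of hydrogen on an aromatic carbon of the ring that hangs from the shared core.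

Compound 3 `CC(C)CCn1ccc(-c2ccc(Oc3ccncc3)cc2)c(C#N)c1=O` has not yet been measured. Its change from compound 1 is (pyridin-4-yl)oxy in place of hydrogen on an aromatic carbon. Among the measured compounds shown here, it is a much larger group than the methoxy of compound 2, but it likewise brings an ether oxygen onto that same ring of carbon only in place of hydrogen, so the step from compound 1 to compound 2 is the only guide at hand. On that guide a lowering of the number in this assay is expected, of roughly similar size, though the wide uncertainty of a single precedent must be kept in mind.

Compound 3 is therefore expected to give about 2800 nM, within a range from 900 nM to 9000 nM. The step this estimate means is expected to be a 3.0-fold lower number from compound 1 to compound 3 (0.48 log units; beyond the scatter).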

Compound 3, half-maximal effective concentration: 550 nM
Beside the measured number, compound 3's estimate is 5.1-fold (0.71 log units) above it; the whole stated range lies above it.
By their numbers in this assay, from the lowest: compound 3; then compound 2; then compound 1.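

On the aromatic ring of carbon only, the position para to a large group accepts a (pyridin-4-yl)oxy group of 7 heavy atoms, and in this assay the change gives a 15-fold lower number from compound 1 to compound 3 (1.19 log units; beyond the scatter) and not a loss. That large step stands against the modest 2.7-fold lower number from compound 1 to compound 2 (0.43 log units; beyond the scatter) on the same ring, so a substituent here can move the number much further than the methoxy result alone showed, although compound 2 carries its methoxy on another carbon and the two steps therefore differ in both group and place. Nothing measured here accounts for the size of the new step.

Still open, on these data alone, is whether the lower number of compound 3 belongs to the place on the ring, the ether oxygen, the pyridine nitrogen or simply the larger group: a methoxy group on this same carbon, or a phenoxy group with carbon in place of the pyridine nitrogen, would help to separate these. Also open, as far as these compounds go, is how an amine or a carboxylic acid on this carbon would behave on this read-out.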